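Chloro for methyl on the aryl group: expected binding

The source may hold more compounds than are shown below. What is called first, only, known or untested is meant among the compounds shown, and "the series" means these compounds.

Measured so far:
compound 1, `CCCn1c(=O)c2nc(-c3ccc(S(=O)(=O)NCCCC(=O)OCC)cc3)[nH]c2n(CCC)c1=O`, 0.24 nM
compound 2, `Cc1ccc(-c2nc3c(=O)n(C)c(=O)n(C)c3[nH]2)c(N)c1`, 10 nM

Both compounds share a core that carries an aromatic ring. In an assay for binding affinity to adenosine receptor A1 (Bos taurus) (a lower number here means a stronger inhibitor, a higher number a weaker inhibitor), compound 1 gives 0.24 nM, while compound 2 gives 10 nM. Of these two numbers, compound 2 has the higher one, and the gap to compound 1 lies beyond the usual scatter of the measurement.

Compound 3, `Cn1c(=O)c2nc(-c3ccc(Cl)cc3N)[nH]c2n(C)c1=O`, has not yet been measured. It differs from compound 2 in one place: chloro in place of methyl on an aromatic carbon. The chloro enters on an aromatic carbon of a six-membered aromatic ring of carbon only, meta to an amino group and para to a large group, where the methyl leaves.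

For the measured compounds named here, no measured pair shows this exact exchange, so there is no step to lean on. The expected step of no change at the digits printed from compound 2 to compound 3 (within the scatter) is small, not beyond the scatter. Compound 3 is therefore estimated at 10 nM, with a range from 3 nM to 30 nM.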

Compound 3, half-maximal inhibitory concentration: 0.35 nM
Beside the measured number, compound 3's estimate is 29-fold (1.46 log units) above it; the whole stated range lies above it.
By their numbers in this assay, from the lowest: compounds 1 and 3 (each within the scatter of the next); then compound 2.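

Exchanging methyl for chloro on this aromatic carbon, meta to an amino group and para to a large group, is far from a neutral swap in this assay, with a 29-fold lower number from compound 2 to compound 3 (1.46 log units; beyond the scatter) for the change of one heavy atom. The counts show no gain or loss of hydrogen-bond donors, hydrogen-bond acceptors or net charge, so this position can strongly affect the read-out even when those counts stay the same. Nothing measured here accounts for the size of this step.

With only methyl and chloro shown at this position, it remains open whether fluoro, bromo or methoxy there would give a number closer to that of compound 2 or compound 3. Going by these compounds, it is also open whether the same exchange would produce a similar step on a core carrying two propyl chains, as compound 1 does.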